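The source may hold more compounds than are shown below. What is called first, only, known or untested is meant among the compounds shown, and "the series" means these compounds.

In an assay on a protein complex for inhibition of ubiquitin carboxyl-terminal hydrolase 1/WD repeat-containing protein 48 (Homo sapiens), read by fluorescence (a lower number here means a stronger inhibitor, a higher number a weaker inhibitor), compound 3 `FC(F)(F)c1ccccc1-c1nc(NCc2ccc(-c3cccc(Cl)c3)cc2)c2ccccc2n1` gives 2700 nM. Among the compounds with values here, that is the lowest of the three numbers so far, but only narrowly: compound 1 `FC(F)(F)c1ccccc1-c1nc(NCc2ccccc2)c2ccccc2n1` gives 3100 nM in this assay, and compound 2 `Fc1ccc(CNc2nc(-c3ccccc3C(F)(F)F)nc3ccccc23)cc1` gives 3400 nM, and each gap is within the scatter. The three steps among them tell the same story: a 1.1-fold higher number from compound 1 to compound 2 (0.04 log units; within the scatter), a 1.1-fold lower number from compound 1 to compound 3 (0.06 log units; within the scatter) and a 1.3-fold lower number from compound 2 to compound 3 (0.10 log units; within the scatter). Changes on the aromatic carbon of the benzyl group, whether a fluoro or a 3-chlorophenyl, have so far moved nothing beyond the scatter.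

Compound 4 `FC(F)(F)c1ccccc1-c1nc(NCc2ccc(-c3cncnc3)cc2)c2ccccc2n1` differs from compound 3 in one place: pyrimidin-5-yl in place of 3-chlorophenyl on an aromatic carbon. Within the data shown here, the only comparison that bears on this is the same position, where a 1.1-fold lower number from compound 1 to compound 3 (0.06 log units; within the scatter) and a 1.3-fold lower number from compound 2 to compound 3 (0.10 log units; within the scatter) both stayed flat, so compound 4 is expected to land close to compound 3, with no step beyond the scatter in this assay in either direction, an expected step of a 1.1-fold higher number from compound 3 to compound 4 (0.05 log units; within the scatter). Compound 4 is therefore estimated at 3000 nM in this assay, within a range from 1200 nM to 8000 nM.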

Compound 4, half-maximal inhibitory concentration: 3000 nM
Beside the measured number, compound 4's estimate shows no gap at the digits printed, within the range that was stated.
By their numbers in this assay, from the lowest: compounds 3, 4, 1 and 2 (each within the scatter of the next).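

Replacing the carbon-only 3-chlorophenyl ring with pyrimidin-5-yl, which brings 2 hetero atoms and 2 hydrogen-bond acceptors, leaves the number in this assay flat, with a 1.1-fold higher number from compound 3 to compound 4 (0.05 log units; within the scatter). Within the data shown here, the same holds against the two smaller groups at this carbon, with a 1.1-fold lower number from compound 2 to compound 4 (0.05 log units; within the scatter) and a 1.0-fold lower number from compound 1 to compound 4 (0.01 log units; within the scatter), so hydrogen, fluoro and both six-membered aromatic rings now all lie within the scatter of one another, a range the earlier compounds had not extended to a ring with hetero atoms. No measurement in hand accounts for this flatness.

The compounds shown leave open whether an amine or a carboxylic acid on this aromatic carbon would move the number beyond the scatter. They also leave open whether replacing the trifluoromethyl group would shift a number that has not yet moved here.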